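The source may report more compounds than this note shows. Statements on the series, on what has been measured and on what is new or still open speak of the compounds shown alone.

Three compounds share one core and differ only in the aryl group attached to a carbonyl carbon. Compound 1 `CN(C(=O)NC(=O)c1ccc(Cl)cc1Cl)c1nc(C(F)(F)F)c(C(=O)N/N=C/c2ccc(C(F)(F)F)cc2)s1` gives 3.08 ug/mL in a functional assay on BCG823 cells (Homo sapiens) for inhibition, read by MTT assay, with a stated time of 72 h; a lower number here means a stronger inhibitor, a higher number a weaker inhibitor. Compound 2 `CN(C(=O)NC(=O)c1cccc(C(F)(F)F)c1)c1nc(C(F)(F)F)c(C(=O)N/N=C/c2ccc(C(F)(F)F)cc2)s1` gives 4.22 ug/mL in this assay, and compound 3 `CN(C(=O)NC(=O)c1ccccc1F)c1nc(C(F)(F)F)c(C(=O)N/N=C/c2ccc(C(F)(F)F)cc2)s1` gives 3.87 ug/mL in this assay. Compound 2 lies within the scatter of both of its neighbours: the step of a 1.4-fold higher number from compound 1 to compound 2 (0.14 log units; within the scatter) and the step of a 1.1-fold lower number from compound 2 to compound 3 (0.04 log units; within the scatter) are each too small to count as a real difference, and the same holds for a 1.3-fold higher number from compound 1 to compound 3 (0.10 log units; within the scatter).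

The untested compound 4 `CN(C(=O)NC(=O)c1cccc(C(F)(F)F)c1)c1nc(C(F)(F)F)c(C(=O)N/N=C/c2cccc(C(F)(F)F)c2)s1` leaves the carbonyl-linked aryl group of compound 2 untouched and instead changes the other end of the molecule: 3-(trifluoromethyl)phenyl in place of 4-(trifluoromethyl)phenyl on a carbon with a double bond to nitrogen. Among the compounds with values here, none of the three measured steps alters the group on that carbon with a double bond to nitrogen, so no measured step bears directly on this change. What the data do show is that moving a trifluoromethyl between ring positions, or swapping halogens, on the carbonyl-linked ring left this assay unchanged beyond the scatter in every case. On that basis compound 4 is expected to give about 4.2 ug/mL in this assay, with a range of 2.1 ug/mL to 8.4 ug/mL. The step of a 1.0-fold lower number from compound 2 to compound 4 (0.00 log units; within the scatter) is estimated to stay within the scatter, with no clear direction.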

Compound 4, half-maximal inhibitory concentration: 4.6 ug/mL
For compound 4 the middle estimate is 1.1-fold (0.04 log units) below the measured one; the measured number falls inside the stated range.
By their numbers in this assay, from the lowest: compounds 1, 3, 2 and 4 (each within the scatter of the next).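

Within the data shown here, this is the first measured change at the far end of the molecule, and in this assay the exchange of 4-(trifluoromethyl)phenyl for 3-(trifluoromethyl)phenyl on a carbon with a double bond to nitrogen gives a 1.1-fold higher number from compound 2 to compound 4 (0.04 log units; within the scatter). The earlier steps shown here all concerned the aryl group on a carbonyl carbon, so they said nothing about this place; now one pair, with the same atoms joined differently, shows no change beyond the scatter here as well. No measurement at hand offers an explanation for this result.

The compounds shown test only this one exchange at this place, with the trifluoromethyl kept on the ring, so it remains open whether an amine or a carboxylic acid on that ring, or a longer chain in place of the ring, would move the number in this assay beyond the scatter. Going by these compounds, it is also open whether the same exchange would leave the number as steady with 2,4-dichlorophenyl or 2-fluorophenyl on the carbonyl carbon.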